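Nitro on the lactam benzyl ring: a pair of series

The source may report more compounds than this note shows. Statements on the series, on what has been measured and on what is new or still open speak of the compounds shown alone.

Compound 1 `N=C(NCc1ccccc1)[C@@H]1CCC(=O)N1Cc1ccccc1` is the parent; in a functional assay on SH-SY5Y cells (Homo sapiens) for cytotoxicity, read by MTT assay, with stated times of 8 h, 30 min and 12 h, tested at 0.05 uM (a higher number here means a stronger effect of the compound at the concentration tested, a lower number a weaker effect), compound 1 gives 16.6%. Compound 2 `COc1ccc(CNC(=N)[C@@H]2CCC(=O)N2Cc2ccccc2)cc1` gives 7.1%, the change being a number 9.5 percentage points lower from compound 1 to compound 2 (within the scatter). Compound 3 `COc1ccc(CNC(=N)[C@@H]2CCC(=O)N2Cc2ccccc2[N+](=O)[O-])cc1` gives 18.1%, and the step of a number 11 percentage points higher from compound 2 to compound 3 (beyond the scatter) is read as nitro in place of hydrogen on an aromatic carbon.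

Compound 4 `N=C(NCc1ccccc1)[C@@H]1CCC(=O)N1Cc1ccc([N+](=O)[O-])cc1` is not yet measured. Its difference from compound 1 is nitro in place of hydrogen on an aromatic carbon. The two cores differ by hydrogen in place of methoxy on an aromatic carbon. The change to compound 4 is the same kind of change as that to compound 3, not the same: in compound 3 the nitro sits ortho to a large group, in compound 4 para to a large group. Among the measured compounds shown here, the step from compound 2 to compound 3 is the only measured guide; a step of similar size, a number 7.4 percentage points higher from compound 1 to compound 4 (within the scatter), is expected for compound 4 because of a number 11 percentage points higher from compound 2 to compound 3 (beyond the scatter), with wide uncertainty given the differing place. Compound 4 is estimated at 24%, between 10% and 38%.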

Compound 4, a percentage reported as activity, at one concentration (the size of the read-out at that concentration, not a potency): 13.7%
Estimate against measurement, compound 4: 10.3 percentage points above; the range from low to high includes it.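

In this assay, nitro in place of hydrogen on an aromatic carbon, para to a large group, gives a number 2.9 percentage points lower from compound 1 to compound 4 (within the scatter). Set beside the step on the methoxy-bearing compound 2, the change does not separate between the two cores: the same change on two cores in this assay, a number 11 percentage points higher (beyond the scatter) from compound 2 to compound 3 and a number 2.9 percentage points lower (within the scatter) from compound 1 to compound 4, 13.9 percentage points apart, within the scatter of two such steps. Among the compounds shown here, this does not establish that the change carries over with a common size, as only two steps are available and they differ in both the core and the place of the nitro on the ring.

On these data alone, it remains open whether the core or the place of the nitro governs the size of the step. Also open, as far as these compounds go, is whether an amine or a carboxylic acid at the same place would give a step beyond the scatter.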